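The source may hold more compounds than are shown below. What is called first, only, known or untested is meant among the compounds shown, and "the series" means these compounds.

Compound 1 `Cc1ccc(S(=O)(=O)c2cnc3c(F)cccc3c2-c2cccc(F)c2)cc1F`: 3.92 mL/min
Compound 2 `COc1cccc(-c2c(S(=O)(=O)c3ccc(OC)c(Cl)c3)cnc3cc(F)ccc23)c1`: 1.71 mL/min

In an ADME assay on microsomes from liver (Homo sapiens) for metabolic stability, tested at 2.5 uM (on this read-out higher numbers stand for fast clearance and lower numbers for slow clearance), compound 1 gives 3.92 mL/min, the highest of the two numbers, while compound 2 gives 1.71 mL/min, a gap beyond the usual scatter. Compound 3 `Cc1ccc(S(=O)(=O)c2cnc3c(F)cccc3c2-c2ccc(Cl)cc2)cc1F` has not yet been measured. It differs from compound 1 by 4-chlorophenyl in place of 3-fluorophenyl on an aromatic carbon. Within the data shown here, no step between measured compounds covers this change, so nothing measured anchors it. The step expected is a 1.1-fold higher number from compound 1 to compound 3 (0.06 log units; within the scatter), a small rise that stays within the scatter. Compound 3 is therefore expected to give 4.5 mL/min, with a range from 2.2 mL/min to 9 mL/min.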

Compound 3, intrinsic clearance in a liver preparation (reported as CLH), per the amount of preparation that the assay uses: 2.2 mL/min
Estimate against measurement, compound 3: 2.0-fold (0.31 log units) above; low and high end bracket the measured number.
By their numbers in this assay, from the lowest: compounds 2, 3 and 1 (each within the scatter of the next, the first and the last beyond it).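

In this assay, among these compounds, 4-chlorophenyl in place of 3-fluorophenyl on this aromatic carbon gives a 1.8-fold lower number from compound 1 to compound 3 (0.25 log units; within the scatter) and is the first change in one place that can be read. At this position, opposite the ring nitrogen, the read-out therefore does not tell these two aryl groups apart, although this rests on a single pair.

As far as these compounds go, what an amine or a carboxylic acid would give on this carbon stays open, as does the same change on other cores. Nothing available speaks to what lies behind this step.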